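A few compounds are considered here, and "the series" means these few. Any claim that something is new, unique, unknown or untested is made for them only; others in the source may bear on it.

In a functional assay on DU-145 cells (Homo sapiens) for antiproliferative activity, read by sulforhodamine B assay, with a stated time of 48 h (on this read-out lower numbers stand for stronger inhibition and higher numbers for weaker inhibition), compound 1, `CCCCN(C)C(=O)CCCOc1cc(OC)c(OC)c2oc(-c3ccc(OC)cc3)c(O)c(=O)c12`, gives > 40000 nM, which is a limit of the assay and not a number. Compound 2, `COc1ccc(-c2oc3c(OC)c(OC)cc(OCCCCCC(=O)NCc4ccccn4)c3c(=O)c2O)cc1`, gives > 40000 nM, and this too is a limit. The whole record so far is therefore (the limit of > 40000 nM in this assay, at which 2 of the 2 values shown sit). Going by the values given here, the single measured step, a step that the two limits leave unreadable from compound 1 to compound 2, has a limit at each end and yields no size, although it changes the side chain on the shared core.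

Compound 3, `COc1ccc(-c2oc3c(OC)c(OC)cc(OC(C)CN(C)C)c3c(=O)c2O)cc1`, keeps that core and carries 1-((dimethylamino)methyl)ethyl in place of 3-(butyl(methyl)carbamoyl)propyl on an oxygen on an aromatic ring. Among the compounds with values here, no measured step bears on this exchange with a readable size, so the expectation remains cautious. Compound 3 is expected to stay weak in this assay, close to the limit that compound 1 shows at > 40000 nM, with any real change running toward stronger inhibition. The expected size is an at least 1.6-fold lower number from compound 1 to compound 3 (0.20 log units; that floor lies within the scatter). For compound 3 the estimated value is 25000 nM, with an expected range from 8000 nM to 40000 nM.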

Compound 3, half-maximal inhibitory concentration: 4380 nM
Estimate against measurement, compound 3: 5.7-fold (0.76 log units) above; measured number below the stated range.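

In this assay compound 3 gives 4380 nM, a measured number and not a limit, so a side chain on this oxygen on an aromatic ring of the shared core can leave readable antiproliferative activity. Putting 1-((dimethylamino)methyl)ethyl in place of 3-(butyl(methyl)carbamoyl)propyl there gives an at least 9.1-fold lower number from compound 1 to compound 3 (0.96 log units; beyond the scatter), the only readable size in the series, and that size is a floor. The step from compound 1 to compound 2 cannot be read, and the other two compounds show only this: the limit of > 40000 nM in this assay, at which 2 of the 3 values shown sit.

The exchange alters several things at once: a chain of 11 heavy atoms holding a carbonyl leaves, and one of 6 heavy atoms with a dimethylamino group and a branch enters, so the compounds shown do not separate the share of the amine, the branch or the chain length in the step. Also open, on these data alone, is how an unbranched 2-(dimethylamino)ethyl chain, or a ring amine such as piperidine or morpholine on the same oxygen, would compare with compound 3.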